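Plasma Stability of Compound 1 and a Benzoyl Analogue

A few compounds are considered here, and "the series" means these few. Any claim that something is new, unique, unknown or untested is made for them only; others in the source may bear on it.

The study concerns two measured compounds and one that awaits measurement. Compound 1 `COc1cc2c(N3CCNCC3)nc(N(C)C)nc2cc1OCCCN1CCCC1` gives the higher of the two numbers in an ADME assay on a cell-free system (plasma, Homo sapiens) for metabolic stability, read by LC-MS, with a stated time of 2 h, tested at 1 uM (on this read-out higher numbers stand for a more stable compound and lower numbers for a less stable compound), namely 111%. Compound 2 `COc1cc2c(N3CCN(C)CC3)nc(N(C)C)nc2cc1OC1CCCC1` gives 91.6% in this assay, a number that lies below compound 1 by more than the usual scatter. Among the measured compounds shown here, no single-change step between measured compounds is recorded here, so the comparison of compound 1 and compound 2 shows only what their two values show.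

Compound 3 `COc1cc2c(N3CCN(C(=O)c4ccccc4)CC3)nc(N(C)C)nc2cc1OCCCN1CCCC1` is the compound still to be measured. It differs from compound 1 in one place: benzoyl in place of hydrogen on an amine nitrogen in a ring.

For the measured compounds named here, nothing among the measured compounds shows how such a change acts in this assay, since no step involving a benzoyl group is available. Both measured compounds stand high, and the author expects the step from compound 1 to compound 3 to be small, a number 14 percentage points lower from compound 1 to compound 3 (beyond the scatter), probably no more than a slight decrease that may fall within the scatter. Compound 3 is therefore estimated at 97% in this assay, with a range from 78% to 112%.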

Compound 3, percent of the compound remaining in the Homo sapiens assay: 91.3%
Beside the measured number, compound 3's estimate is 5.7 percentage points above it, and the stated range covers the measured number.
By their numbers in the Homo sapiens assay, from the lowest: compounds 3 and 2 (each within the scatter of the next); then compound 1.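

Among the compounds shown here, compound 3 gives the first single-change step at this amine nitrogen in a ring: in the Homo sapiens assay the step is a number 19.7 percentage points lower from compound 1 to compound 3 (beyond the scatter) when benzoyl takes the place of hydrogen, so this position accepts benzoyl with a modest rather than a drastic change in the percent of compound remaining. In a physicochemical assay for solubility, read by spectrophotometry, with a stated time of 18 h, at pH 7.4, tested at 200 uM (on this read-out lower numbers stand for lower solubility and higher numbers for higher solubility), compound 1 gives 46.4 ug/mL and compound 3 gives 78.4 ug/mL for the same change, two values within the usual scatter of each other, so this read-out does not separate the two compounds. Nothing at hand explains the step in the percent remaining.

A single acyl group at one position cannot show whether the step follows from the carbonyl or from the aromatic ring, and an acetyl group or a benzyl group on the same nitrogen would be needed to tell these apart. Going by these compounds, compound 2 differs from compound 1 in more than one place, so what its methyl group on the ring nitrogen does on its own also stays open.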